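The compounds below may be only part of what the source reports. "The series", "measured", "known", "first", "only" and "open" are said of these compounds alone.

For the measured compounds named here, in a functional assay on A549 cells (Homo sapiens) for inhibition, read by MTT assay, with a stated time of 48 h (on this read-out higher numbers stand for weaker inhibition and lower numbers for stronger inhibition), compound 1 (`COc1cc(-c2nccn3cc(-c4ccc(F)cc4)nc23)cc(OC)c1OC`) gives 137 nM as its value, and compound 2 (`COc1cc(-c2nccn3cc(-c4ccccc4)nc23)cc(OC)c1OC`) gives 378 nM as the highest of the two numbers so far. Compound 3 (`COc1cc(-c2nccn3cc(-c4ccc([N+](=O)[O-])cc4)nc23)cc(OC)c1OC`) is still unmeasured. It differs from compound 2 by nitro in place of hydrogen on an aromatic carbon (nitro in place of hydrogen on an aromatic carbon, para to a large group, phenyl to 4-nitrophenyl). Going by the values given here, only one measured step bears on this change, the replacement of fluoro by hydrogen on an aromatic carbon, which gives a 2.8-fold higher number from compound 1 to compound 2 (0.44 log units; beyond the scatter) as a modest result beyond the scatter. This is a single step involving a different group, and nothing yet shows that nitro will follow fluoro. Taking that step in reverse as the only guide, with compound 1 at 137 nM as the reference, a modest move to a lower number is expected in this assay at about that size or smaller. The expected change is a 1.9-fold lower number from compound 2 to compound 3 (0.28 log units; within the scatter) on this estimate. For compound 3 the estimated value is 200 nM within an expected range of 60 nM to 600 nM in these notes.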

Compound 3, half-maximal inhibitory concentration: > 10000 nM
Compound 3 gave a limit, no number; the forecaster's own chance of this, stated with the estimate: 3%; middle value at least 50-fold (1.69 log units) from the limit.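

In this assay, compound 3 reaches a limit of the assay and gives no number: the limit of > 10000 nM in this assay, at which 1 of the 3 values shown sits.

Putting nitro on the aromatic carbon para to a large group gives an at least 26-fold higher number from compound 2 to compound 3 (1.42 log units; beyond the scatter), and measured against the fluoro analogue the same place gives an at least 72-fold higher number from compound 1 to compound 3 (1.86 log units; beyond the scatter). The earlier pair showed only a modest step at this place, whereas these steps show that the read-out can depend strongly on the group that stands there, and that a substituent does not have to lower the number as fluoro does. Fluoro and nitro move the number in opposite directions from hydrogen, so the three compounds do not support treating any replacement of hydrogen at this place as favourable.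

As far as these compounds go, because compound 3 is a limit, the full size of the step stays unknown, and three compounds cannot show what sets nitro apart from fluoro. From the compounds shown here alone, whether an amine or a carboxylic acid on this carbon would stay close to compound 2 or move towards compound 3 remains open, as does whether nitro on another carbon of the same ring would give the same result.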